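Anilino-substituted vinyl sulfone series: cytotoxicity notes

The source may hold more compounds than are shown below. What is called first, only, known or untested is meant among the compounds shown, and "the series" means these compounds.

Of the compounds shown here, two have been measured in a functional assay on DU-145 cells (Homo sapiens) for cytotoxicity, read by trypan blue exclusion, with a stated time of 96 h; a lower number here means a stronger inhibitor, a higher number a weaker inhibitor. Compound 1, `COc1cc(OC)c(/C=C/S(=O)(=O)Cc2ccc(OC)cc2[N+](=O)[O-])c(OC)c1`, gives 20000 nM in this assay. Compound 2, `COC(=O)C(C)(C)Nc1cc(CS(=O)(=O)/C=C/c2c(OC)cc(OC)cc2OC)ccc1OC`, gives 2500 nM in this assay. Among the measured compounds shown here, on these two numbers compound 2 stands lowest, with compound 1 the only neighbour, and the gap between them lies beyond the scatter.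

The next compound, compound 3, is `COc1cc(OC)c(/C=C/S(=O)(=O)Cc2ccc(OC)c(NC(C(=O)O)c3ccccc3)c2)c(OC)c1`. It differs from compound 2 at one place:

carboxy(phenyl)methyl in place of 1-(methoxycarbonyl)-1-methylethyl on a nitrogen on an aromatic ring

The change sits on a nitrogen on an aromatic ring whose other neighbours are aromatic carbon, and the entering group brings one six-membered aromatic ring of carbon only together with one hydrogen-bond donor where the leaving group had none. For the measured compounds named here, no measured pair shows such a change, so nothing here fixes its size or direction.

For compound 3 the expected value in this assay is 4000 nM, with a range from 1000 nM to 16000 nM. This estimate means a step of a 1.6-fold higher number from compound 2 to compound 3 (0.20 log units; within the scatter), expected to be modest, toward a weaker inhibitor or nothing beyond the scatter.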

Compound 3, half-maximal inhibitory concentration: 20 nM
Beside the measured number, compound 3's estimate is 200-fold (2.30 log units) above it; the whole stated range lies above it.
By their numbers in this assay, from the lowest: compound 3; then compound 2; then compound 1.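

Among the compounds shown here, the nitrogen on an aromatic ring proves a highly sensitive place in this assay, where carboxy(phenyl)methyl in place of 1-(methoxycarbonyl)-1-methylethyl gives a 130-fold lower number from compound 2 to compound 3 (2.10 log units; beyond the scatter) and supplies the first measured step at this position. The exchange alters several things at once: the entering group brings a six-membered aromatic ring of carbon only and a hydrogen-bond donor, and it swaps the methyl ester and the gem-dimethyl carbon for a free carboxylic acid and a phenyl-bearing carbon, so the step can be read only for the exchange as a whole and not for any one of these features. No measurement available here bears on why the step is so large.

The compounds shown leave open which part of the entering group carries the step, the six-membered aromatic ring or the free carboxylic acid. A methyl ester of carboxy(phenyl)methyl and a plain carboxymethyl group on the same nitrogen would each help to separate those two contributions.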